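Meta-substituted benzamides on the shared core: nitro analogue

The source may report more compounds than this note shows. Statements on the series, on what has been measured and on what is new or still open speak of the compounds shown alone.

Compound 1 `COc1cccc(C(=O)Nc2cc(Sc3ncn[nH]3)c(O)c3ccccc23)c1` carries a methoxy on the benzamide ring of the shared core. In a functional assay on HCT-116 cells (Homo sapiens) for antiproliferative activity, read by MTT assay, with a stated time of 48 h (on this read-out lower numbers stand for stronger inhibition and higher numbers for weaker inhibition), compound 1 gives only a limit of the assay, > 100000 nM, and no number. Compound 2 `O=C(Nc1cc(Sc2ncn[nH]2)c(O)c2ccccc12)c1cccc(Cl)c1` also returns only the limit, > 100000 nM. Compound 3 `Cc1cccc(C(=O)Nc2cc(Sc3ncn[nH]3)c(O)c3ccccc23)c1` likewise returns only the limit, > 100000 nM. Compound 1 therefore stands at the limit shared by all three measured compounds, with no number to place it above or below the others; this is the whole of the evidence here (the limit of > 100000 nM in this assay, at which 3 of the 3 values shown sit).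

The steps among the measured compounds are unreadable: a step that the two limits leave unreadable from compound 1 to compound 2, a step that the two limits leave unreadable from compound 1 to compound 3 and a step that the two limits leave unreadable from compound 2 to compound 3. None of them shows a direction or a size.

Compound 4 `O=C(Nc1cc(Sc2ncn[nH]2)c(O)c2ccccc12)c1cccc([N+](=O)[O-])c1` differs from compound 1 in one place: nitro in place of methoxy on an aromatic carbon. Within the data shown here, the three unreadable steps bear on this change only in that every variation at this position so far has stayed at the limit, so no step beyond the scatter is expected in this assay in either direction. The expected step is a number no higher from compound 1 to compound 4 (the limit leaves the size open). Compound 4 is therefore expected to give about 100000 nM, within 30000 nM to 300000 nM, most likely again as a limit rather than a number.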

Compound 4, half-maximal inhibitory concentration: 70200 nM
Compound 4: the middle estimate sits 1.4-fold (0.15 log units) above what was measured; low and high end bracket the measured number.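

Nitro is the first group at this position to return a number rather than a limit in this assay, and the steps read as an at least 1.4-fold lower number from compound 1 to compound 4 (0.15 log units; that floor lies within the scatter), an at least 1.4-fold lower number from compound 3 to compound 4 (0.15 log units; that floor lies within the scatter) and an at least 1.4-fold lower number from compound 2 to compound 4 (0.15 log units; that floor lies within the scatter). As far as these compounds go, each of these steps is only a floor set against a limit, so its true size stays open, and the floors alone do not separate compound 4 from the other three compounds. Of the four groups at this position, only nitro yields a number, and the rest of the set stays where it was: the limit of > 100000 nM in this assay, at which 3 of the 4 values shown sit.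

Whether nitro truly outperforms methoxy, chloro and methyl at this position remains unresolved. Also open, from the compounds shown here alone, is what an amine or a carboxylic acid would give here, and whether any group at this position reaches a value well clear of the limit.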